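The compounds below may be only part of what the source reports. "The series", "measured", "known", "first", "only" and "open" are said of these compounds alone.

Measured compounds:
Compound 1 `COc1cc(NC(C)CCCNC(=O)NNC(=O)NCCO)c2ncccc2c1` — in a functional assay on HeLa cells (Homo sapiens) for inhibition, read by MTT assay, with a stated time of 4 days (a lower number here means a stronger inhibitor, a higher number a weaker inhibitor), compound 1 gives 196000 nM.
Compound 2 `COc1cc(NC(C)CCCNC(=O)NNC(=O)NC(CO)(CO)CO)c2ncccc2c1` — in this assay compound 2 gives > 250000 nM, which is a limit of the assay, not a number.

Compound 2 therefore stands at the edge of what the assay can report, at the limit of > 250000 nM in this assay, at which 1 of the 2 values shown sits, and is a very weak inhibitor on the values shown. The unmeasured compound 3 `COc1cc(NC(C)CCCNC(=O)NNC(=O)N(CCO)CCO)c2ncccc2c1` differs from compound 2 by bis(2-hydroxyethyl)amino in place of (2-hydroxy-1,1-bis(hydroxymethyl)ethyl)amino on a carbonyl carbon. For the measured compounds named here, the only measured step that bears on this change is an at least 1.2-fold higher number from compound 1 to compound 2 (0.10 log units; that floor lies within the scatter), whose floor sits within the scatter, so it gives no firm direction. Compound 3 carries two 2-hydroxyethyl groups where compound 1 carries one, so a number close to compound 1 is expected, with a step of an at least 1.1-fold lower number from compound 2 to compound 3 (0.05 log units; that floor lies within the scatter) expected from the limit of compound 2 toward a measurable value. For compound 3 the expected value is 220000 nM, within 120000 nM to 400000 nM, with a real chance that only a limit is reported again.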

Compound 3, half-maximal inhibitory concentration: > 250000 nM
Compound 3 was reported as a limit (the forecaster's own chance of this, stated with the estimate: 45%); middle value at least 1.1-fold (0.05 log units) away from the limit.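

In this assay compound 3 is reported as a limit, as compound 2 is, so the step for bis(2-hydroxyethyl)amino in place of (2-hydroxy-1,1-bis(hydroxymethyl)ethyl)amino on this carbonyl carbon cannot be read. Setting 2-hydroxyethyl in place of hydrogen on the amide-type nitrogen gives an at least 1.2-fold higher number from compound 1 to compound 3 (0.10 log units; that floor lies within the scatter) and so shows no firm direction for this second change. Two different replacements of the group on this carbonyl carbon now end at the same limit of the assay: the limit of > 250000 nM in this assay, at which 2 of the 3 values shown sit.

Whether compound 2 and compound 3 truly differ stays hidden behind their limits. As far as these compounds go, only compound 1 gives a true number, 196000 nM in this assay, and whether an amine, a carboxylic acid or a longer chain in this place would move that number clearly remains open.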